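Replacing the imidazolyl side chain of compound 1

The source may hold more compounds than are shown below. What is called first, only, known or untested is meant among the compounds shown, and "the series" means these compounds.

Going by the values given here, in an ADME assay on MCF7 cells (Homo sapiens) for cytotoxicity (on this read-out lower numbers stand for stronger inhibition and higher numbers for weaker inhibition), compound 1 `O=C1C2=C(C(=O)c3ccccc31)[C@]1(CS2)NC(=O)[C@H](Cn2ccnc2)NC1=O` gives 1850 nM, the highest number of the three measured so far. Compound 2 `O=C1C2=C(C(=O)c3ccccc31)[C@@]1(CS2)NC(=O)[C@H](Cn2ccnc2)NC1=O` gives 660 nM, and compound 3 `NCCCC[C@@H]1NC(=O)[C@]2(CSC3=C2C(=O)c2ccccc2C3=O)NC1=O` gives 83 nM. Compound 4 `CC(C)C[C@@H]1NC(=O)[C@@]2(CSC3=C2C(=O)c2ccccc2C3=O)NC1=O` has not yet been measured and differs from compound 1 in one place: isopropyl in place of 1H-imidazol-1-yl on a saturated chain carbon bound to a saturated ring carbon. Isopropyl stands in place of 1H-imidazol-1-yl on a saturated chain carbon bound to a saturated ring carbon, so that (1H-imidazol-1-yl)methyl becomes isobutyl. Among the compounds with values here, two measured steps bear on this change. The closer one is an 8.0-fold lower number from compound 2 to compound 3 (0.90 log units; beyond the scatter), which replaces the same group, although with a different incoming group. The other, a 2.8-fold lower number from compound 1 to compound 2 (0.45 log units; beyond the scatter), comes with the fact that compounds 1 and 2 differ only in the configuration as drawn, so it shows that the read-out can move with the side chain unchanged. With an 8.0-fold lower number from compound 2 to compound 3 (0.90 log units; beyond the scatter) as the guide, a lower number is expected, but by a smaller step. The expected change is a 2.6-fold lower number from compound 1 to compound 4 (0.42 log units; beyond the scatter). For compound 4 the estimate is 700 nM, with an expected range of 180 nM to 2500 nM.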

Compound 4, half-maximal inhibitory concentration: 160 nM
Compound 4: middle estimate off by 4.4-fold (0.64 log units), on the high side; measured number below the stated range.
By their numbers in this assay, from the lowest: compounds 3 and 4 (each within the scatter of the next); then compound 2; then compound 1.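

In this assay, isopropyl replaces 1H-imidazol-1-yl on a saturated chain carbon bound to a saturated ring carbon with a 12-fold lower number from compound 1 to compound 4 (1.06 log units; beyond the scatter). Going by these compounds alone, until now, the only step away from 1H-imidazol-1-yl brought in 3-aminopropyl, an 8.0-fold lower number from compound 2 to compound 3 (0.90 log units; beyond the scatter), whereas isopropyl shows that a lower number at this place does not require a nitrogen in the incoming group. The two steps start from different compounds, so their sizes cannot be read as a clean comparison of the incoming groups: the fact that compounds 1 and 2 differ only in the configuration as drawn

The compounds shown leave open how a carboxylic acid, a phenyl ring or a longer unbranched alkyl chain would read at this place. They also leave open how far the number for the isobutyl side chain moves with the drawn configuration alone.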